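Cytotoxicity notes on compounds 1 to 4

A few compounds are considered here, and "the series" means these few. Any claim that something is new, unique, unknown or untested is made for them only; others in the source may bear on it.

Compound 1 `c1ccc(-c2ccc(Cn3cncc3CNc3ccc(-c4onc5ccccc45)c(-c4ccccc4)c3)cc2)cc1` was tested in a toxicity assay on NIH3T3 cells (Mus musculus) for cytotoxicity, read by resazurin assay; a higher number here means that more compound is needed for the effect, a lower number that less compound is needed. In this assay compound 1 gives only a limit, > 10000 nM, and not a number. This is the limit of > 10000 nM in this assay, at which 1 of the 3 values shown sits. Compound 2 `COC(=O)c1ccc(NCc2cncn2Cc2ccccc2N)cc1-c1ccccc1` gives 25000 nM in this assay. For compound 3 `COC(=O)c1ccc(NCc2cncn2Cc2ccccc2OC)cc1-c1ccccc1` the result in this assay is "not determined" (no result reported). Compound 4 `COC(=O)c1ccc(NCc2cncn2Cc2ccc(-c3ccccc3)cc2)cc1-c1ccccc1` has not yet been measured. It differs from compound 1 in one place: a group of 4 heavy atoms (2 carbon, 2 oxygen; no ring) in place of a group of 9 heavy atoms (7 carbon, 1 nitrogen, 1 oxygen; one five-membered aromatic ring with 2 hetero atoms, one six-membered aromatic ring of carbon only), on an aromatic carbon. Among the compounds with values here, no step between measured compounds is known here, so the direction of the change is open; compound 2, which also carries the methoxycarbonyl group, shows weak cytotoxicity with 25000 nM, and a step beyond the scatter is not expected. Compound 4 is therefore estimated at 20000 nM, between 8000 nM and 50000 nM, meaning an expected step that the limit leaves unreadable from compound 1 to compound 4.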

Compound 4, half-maximal effective concentration: > 1000 nM
Compound 4: no number, only a limit (the forecaster's own chance of this, stated with the estimate: 50%); the middle value does not contradict the limit.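

In this assay compound 4 gives only a limit, > 1000 nM; the steps from compound 1 and compound 2 to compound 4 cannot be read. The compounds shown leave open whether methoxycarbonyl in place of the group in compound 1 changes cytotoxicity at all.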